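Aryl Exchange on the Ring Amine: Inhibition Expected to Stay Low

This account rests on a few compounds, and the source may have more. Where it says the series, first, only, none or still open, it means among the compounds named here.

Compound 3 `Nc1scc(CN2CCN(c3ccc(F)c(F)c3)CC2)c1C(=O)c1ccc(Cl)cc1` gives 1% in an assay on CHO cells for displacement of a labelled ligand from adenosine receptor A3 (Homo sapiens), read by scintillation counting, with a stated time of 120 min, tested at 10 uM; a higher number here means more inhibition at the concentration tested (going by the name of the read-out), a lower number less inhibition. Compound 1 `Nc1scc(CN2CCN(c3ccc(Cl)cc3F)CC2)c1C(=O)c1ccc(Cl)cc1` gives 1% in this assay, and compound 2 `Nc1scc(CN2CCN(C3CCCCCC3)CC2)c1C(=O)c1ccc(Cl)cc1` gives 0%; the steps of no change at the digits printed from compound 1 to compound 3 (within the scatter) and a number 1 percentage points higher from compound 2 to compound 3 (within the scatter) lie within the scatter, so compound 3 stands level with compound 1 and close to compound 2. Compound 4 `Nc1scc(CN2CCN(c3c(Cl)cccc3Cl)CC2)c1C(=O)c1ccc(Cl)cc1` differs from compound 3 by 2,6-dichlorophenyl in place of 3,4-difluorophenyl on an amine nitrogen in a ring. The steps bearing on this exchange are a number 1 percentage points lower from compound 1 to compound 2 (within the scatter) and no change at the digits printed from compound 1 to compound 3 (within the scatter): neither exchange of the group on the ring amine moved the read-out beyond the scatter. No step beyond the scatter is therefore expected in this assay; the estimated step is no change at the digits printed from compound 3 to compound 4 (within the scatter). Compound 4 is expected to give 1%, between 0% and 10%.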

Compound 4, a percentage reported as inhibition, at one concentration (the size of the read-out at that concentration, not a potency): 1%
For compound 4 middle estimate and measured number coincide at the digits printed; measured number inside the range.
By their numbers in this assay, from the lowest: compounds 2, 1, 3 and 4 (each within the scatter of the next).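

In this assay the 2,6-dichlorophenyl group behaves like the groups already seen on the ring amine, with no change at the digits printed from compound 3 to compound 4 (within the scatter) and no change at the digits printed from compound 1 to compound 4 (within the scatter) among the aryl groups, and a number 1 percentage points higher from compound 2 to compound 4 (within the scatter) against cycloheptyl. Two chlorine atoms in place of two fluorine atoms on the phenyl ring therefore leave the read-out within the scatter. The data offer no explanation for this flat result. From the compounds shown here alone, whether an amine or a carboxylic acid on the aryl ring, or a longer chain in its place, would raise the read-out stays open. So does the effect of changes elsewhere on the shared core.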